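A few compounds are considered here, and "the series" means these few. Any claim that something is new, unique, unknown or untested is made for them only; others in the source may bear on it.

Measured so far:
- compound 1, `CCN(CC)Cc1ccc(/C=C2\COc3cc(OC)c(OC)cc3C2=O)cc1O`, gives 2430 nM in an assay on isolated protein for inhibition of Amine oxidase [flavin-containing] B (Homo sapiens), read by fluorescence, with a stated time of 30 min; a higher number here means a weaker inhibitor, a lower number a stronger inhibitor.
- compound 2, `COc1cc2c(cc1OC)C(=O)/C(=C/c1ccc(CN3CCCCC3)c(O)c1)CO2`, gives 1740 nM in this assay.

Among the compounds with values here, on these two numbers compound 1 has the higher one, with compound 2 as its only neighbour; the step of a 1.4-fold lower number from compound 1 to compound 2 (0.15 log units; within the scatter) lies within the scatter, so the two cannot be ordered.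

Compound 3, `COc1ccccc1CN(C)Cc1ccc(/C=C2\COc3cc(OC)c(OC)cc3C2=O)cc1O`, is not yet measured in this assay. Relative to compound 1 the change is (2-methoxybenzyl)(methyl)amino in place of diethylamino on a saturated chain carbon bound to an aromatic carbon.

Within the data shown here, the only measured step that bears on this position is the one from compound 1 to compound 2, a 1.4-fold lower number from compound 1 to compound 2 (0.15 log units; within the scatter), where one amine on the same saturated chain carbon was exchanged for another without a change beyond the scatter. Compound 3 moves further than that: the entering group carries an aromatic ring and a second hydrogen-bond acceptor that neither compound 1 nor compound 2 has, and nothing in the series shows what such a group does here.

The expectation therefore rests on a single neutral step and carries a wide range. A modest step is expected, a 1.6-fold lower number from compound 1 to compound 3 (0.21 log units; within the scatter), with compound 3 estimated at 1500 nM, between 400 nM and 6000 nM.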

Compound 3, half-maximal inhibitory concentration: 1030 nM
Estimate against measurement, compound 3: 1.5-fold (0.16 log units) above; the measured number falls inside the stated range.
By their numbers in this assay, from the lowest: compounds 3, 2 and 1 (each within the scatter of the next, the first and the last beyond it).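

In this assay, within the data shown here, the position on a saturated chain carbon bound to an aromatic carbon shows a change beyond the scatter for the first time, with (2-methoxybenzyl)(methyl)amino in place of diethylamino giving a 2.4-fold lower number from compound 1 to compound 3 (0.37 log units; beyond the scatter); a much larger amine carrying a six-membered aromatic ring of carbon only is therefore accepted here with no loss of inhibition. Against piperidin-1-yl the same group gives a 1.7-fold lower number from compound 2 to compound 3 (0.23 log units; within the scatter), which leaves compound 2 and compound 3 unordered, so the difference can be read only against the diethylamino group of compound 1. No measurement at hand gives a reason for the step.

The compounds shown leave open which part of the entering group accounts for the step, since the aromatic ring, the methoxy group and the N-methyl group all arrive together; benzyl(methyl)amino, without the methoxy group, would separate the first two. Also open, on these data alone, is whether a ring amine with a second heteroatom, such as morpholin-4-yl, would stay level with piperidin-1-yl or follow (2-methoxybenzyl)(methyl)amino.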